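The source may report more compounds than this note shows. Statements on the series, on what has been measured and on what is new or still open speak of the compounds shown alone.

Compound 1 `Cc1nc(SCC(=O)Nc2nc(-c3ccc(Cl)cc3)cs2)n(Nc2ccccc2)c1C`: 5740 nM in a functional assay on HCT-15 cells (Homo sapiens) for antiproliferative activity, read by sulforhodamine B assay, with a stated time of 48 h; a lower number here means a stronger inhibitor of growth, a higher number a weaker inhibitor of growth
Compound 2 `Cc1ccc(Nn2c(SCC(=O)Nc3nc(-c4ccccc4)cs3)nc(C)c2C)cc1`: 5170 nM in this assay

On these two numbers compound 1 has the highest value, and its nearest neighbour is compound 2, whose value lies within the scatter of repeated measurements of this kind, so the two compounds cannot be placed in any order against each other. Compound 3 `COc1ccc(Nn2c(SCC(=O)Nc3nc(-c4ccc(Cl)cc4)cs3)nc(C)c2C)cc1` has not yet been measured in this assay. It differs from compound 1 in one place: methoxy in place of hydrogen on an aromatic carbon. Among the measured compounds shown here, no measured pair in this set shows the effect of such a change, and nothing in the data points to a step beyond the scatter in this assay in either direction. The expected step is a 1.0-fold lower number from compound 1 to compound 3 (0.02 log units; within the scatter), which leaves the value essentially where it was. The estimate for compound 3 in this assay is 5500 nM, with a range from 2500 nM to 12000 nM.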

Compound 3, concentration for 50% growth inhibition: 4790 nM
For compound 3 the middle estimate is 1.1-fold (0.06 log units) above the measured one; the measured number falls inside the stated range.
By their numbers in this assay, from the lowest: compounds 3, 2 and 1 (each within the scatter of the next).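

The methoxy group, entering on an aromatic carbon para to a large group, gives a 1.2-fold lower number from compound 1 to compound 3 (0.08 log units; within the scatter) in this assay. Among the compounds shown here, this is the first single change that can be read in the set, and it shows that going from phenyl to 4-methoxyphenyl at this position leaves the growth inhibition within the scatter, with no order between the two compounds. No independent measurement bears on why the value stays put.

Going by these compounds, one group at one position cannot show how far this flat result extends, so it remains open whether an amine, a carboxylic acid or a longer alkoxy chain at the same place would give a step beyond the scatter. On these data alone, it is equally open whether a change elsewhere on the core of compound 1, such as replacing its chlorine with a methoxy group, would move the value in this assay.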